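From hydroxyphenyl sulfonyl to tetrazole on a urea chain

This account rests on a few compounds, and the source may have more. Where it says the series, first, only, none or still open, it means among the compounds named here.

Measured in a functional assay on Coronary artery (Bos taurus) (a higher number here means that more compound is needed for the effect, a lower number that less compound is needed), as follows
compound 1 `CCCCCNC(=O)NCCCC/C=C\CCCCCS(=O)(=O)c1ccccc1O` gives 5000 nM
compound 2 `CCCCCCC(=O)N(CCCC/C=C\CCCCCCc1nnn[nH]1)C(C)C` gives 1000 nM

Compound 1 holds the higher of the two numbers, and its gap to compound 2 lies beyond the scatter. The move to compound 3 `CCCCCNC(=O)NCCCC/C=C\CCCCCCCc1nnn[nH]1` brings 2-(1H-tetrazol-5-yl)ethyl in place of (2-hydroxyphenyl)sulfonyl on a saturated chain carbon, five bonds along the chain from a double-bonded chain carbon with 2-(1H-tetrazol-5-yl)ethyl in place of (2-hydroxyphenyl)sulfonyl on a saturated chain carbon, five bonds along the chain from a double-bonded chain carbon. For the measured compounds named here, no measured step covers this change. Compound 2 also carries a 1H-tetrazol-5-yl group and gives 1000 nM in this assay, so a lower number is expected. The expected step, beyond the scatter, is an 8.3-fold lower number from compound 1 to compound 3 (0.92 log units; beyond the scatter) as a rough estimate. Compound 3 is estimated at 600 nM (120 nM to 3000 nM).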

Compound 3, half-maximal effective concentration: 1100 nM
The estimate for compound 3 lay 1.8-fold (0.26 log units) below the measured number, within the range that was stated.
By their numbers in this assay, from the lowest: compounds 2 and 3 (each within the scatter of the next); then compound 1.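

In this assay, 2-(1H-tetrazol-5-yl)ethyl in place of (2-hydroxyphenyl)sulfonyl on a saturated chain carbon, five bonds along the chain from a double-bonded chain carbon, gives a 4.5-fold lower number from compound 1 to compound 3 (0.66 log units; beyond the scatter) and so a modest change. This is the first step shown at this position with the rest of the structure held constant. No measurement is at hand that bears on the reason for this step.

The compounds shown do not separate the tetrazole ring from its ethyl link, which enter together, and they leave open how a carboxylic acid in the same place would stand.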